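This account rests on a few compounds, and the source may have more. Where it says the series, first, only, none or still open, it means among the compounds named here.

Measured compounds:
compound 1 `COc1ccc(/C=C/C(=O)Nc2cc3c(Nc4ccc(F)c(Cl)c4)ncnc3cc2OC)c(OC)c1` with 33300 nM
compound 2 `COc1ccc(/C=C/C(=O)Nc2cc3c(Nc4ccc(F)c(Cl)c4)ncnc3cc2O[C@H]2CCOC2)c(OC)c1OC` with 70 nM
compound 3 `COc1ccc(OC)c(/C=C/C(=O)Nc2cc3c(Nc4ccc(F)c(Cl)c4)ncnc3cc2OC)c1` with 11200 nM

In a functional assay on A549 cells (Homo sapiens) for cytotoxicity, read by MTT assay, with a stated time of 72 h (on this read-out higher numbers stand for weaker inhibition and lower numbers for stronger inhibition), compound 2 gives the lowest of the three numbers; compound 3 sits a long way above it, and compound 1 further still. Compound 4 `O=C(/C=C/c1ccccc1[N+](=O)[O-])Nc1cc2c(Nc3ccc(F)c(Cl)c3)ncnc2cc1O[C@H]1CCOC1` has not yet been measured. It differs from compound 2 in one place: 2-nitrophenyl in place of 2,3,4-trimethoxyphenyl on a double-bonded chain carbon bound to a double-bonded chain carbon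

Within the data shown here, only one measured step concerns a swap of the aryl group at this same place, a 3.0-fold lower number from compound 1 to compound 3 (0.47 log units; beyond the scatter), and it is modest. Compound 2 differs from both compound 1 and compound 3 in two places at once, so how much of its advantage rests on the 2,3,4-trimethoxyphenyl group cannot be separated out. Compound 4 keeps the rest of compound 2 unchanged, so the expected outcome is a weaker number than compound 2 but one that stays well clear of compound 1 and compound 3; the step expected from compound 2 to compound 4 is an 8.6-fold higher number from compound 2 to compound 4 (0.93 log units; beyond the scatter). For compound 4 the estimated value in this assay is 600 nM, within a range from 80 nM to 6000 nM.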

Compound 4, half-maximal inhibitory concentration: 8820 nM
For compound 4 the middle estimate is 15-fold (1.17 log units) below the measured one, outside the stated range (above it).
By their numbers in this assay, from the lowest: compound 2; then compounds 4 and 3 (each within the scatter of the next); then compound 1.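

In this assay the swap of 2,3,4-trimethoxyphenyl for 2-nitrophenyl gives a 130-fold higher number from compound 2 to compound 4 (2.10 log units; beyond the scatter) and so shows that the aryl group at this place can by itself decide much of the result. Among these compounds, the only earlier step at this place, a 3.0-fold lower number from compound 1 to compound 3 (0.47 log units; beyond the scatter) for two dimethoxyphenyl groups, was modest, so it gave no sign that a change here could be this large. The rest of compound 4 is the same as in compound 2, so those shared parts do not secure a low number on their own, and no measurement offered here explains the loss.

The swap removes the methoxy groups and brings in a nitro group at once, so the compounds shown leave open which of the two matters more. A plain phenyl or a 2-aminophenyl group at this place would help separate them.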